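This account rests on a few compounds, and the source may have more. Where it says the series, first, only, none or still open, it means among the compounds named here.

Series notes. In a functional assay on HEK293 cells for antagonist activity at P2X purinoceptor 7 (Homo sapiens) (on this read-out lower numbers stand for stronger inhibition and higher numbers for weaker inhibition), compound 1 `N#Cc1ccc(-c2ccc(Cl)c(C(=O)NCC3(O)CCCCCC3)c2)nc1` gives 134 nM. Compound 2 `O=C(NCC1(O)CCCCCC1)c1cc(-c2ccc(Cl)cn2)ccc1Cl` gives 56 nM in this assay, and compound 3 `Cc1cnc(-c2ccc(Cl)c(C(=O)NCC3(O)CCCCCC3)c2)cn1` gives 22 nM, the lowest of the three numbers. The measured steps are a 2.4-fold lower number from compound 1 to compound 2 (0.38 log units; beyond the scatter), a 6.1-fold lower number from compound 1 to compound 3 (0.78 log units; beyond the scatter) and a 2.5-fold lower number from compound 2 to compound 3 (0.41 log units; beyond the scatter), each modest and each beyond the scatter. Compound 4 `O=C(NCC1(O)CCCCCC1)c1cc(-c2ncc(F)cn2)ccc1Cl` carries the change (5-fluoropyrimidin-2-yl in place of 5-methylpyrazin-2-yl on an aromatic carbon). For the measured compounds named here, no measured step exchanges one six-membered aromatic ring with two hetero atoms for another of that kind at the aromatic carbon named in the change; the steps that bear on it swap a substituent or the whole ring there and stay modest. Compound 4 is therefore expected at 40 nM, range 15 nM to 110 nM. The expected step is a 1.8-fold higher number from compound 3 to compound 4 (0.26 log units; within the scatter), modest, toward a higher number or none beyond the scatter.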

Compound 4, half-maximal inhibitory concentration: 16 nM
Compound 4: the middle estimate sits 2.5-fold (0.40 log units) above what was measured, within the range that was stated.
By their numbers in this assay, from the lowest: compounds 4 and 3 (each within the scatter of the next); then compound 2; then compound 1.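

At this aromatic carbon, one six-membered aromatic ring with 2 hetero atoms can replace another in this assay without a change beyond the scatter (a 1.4-fold lower number from compound 3 to compound 4 (0.14 log units; within the scatter)). The same 5-fluoropyrimidin-2-yl group also holds its advantage over 5-chloropyridin-2-yl (a 3.5-fold lower number from compound 2 to compound 4 (0.54 log units; beyond the scatter)) and 5-cyanopyridin-2-yl (an 8.4-fold lower number from compound 1 to compound 4 (0.92 log units; beyond the scatter)), so both diazine-bearing compounds, compound 3 and compound 4, stand below the two pyridinyl compounds. No supporting data bear on why these steps take this size.

As far as these compounds go, the exchange alters ring and substituent together, so their separate shares stay unknown. From the compounds shown here alone, whether a 5-aminopyrimidin-2-yl or an unsubstituted pyrimidin-2-yl group would hold this level also stays open.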